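Working notes: from compound 3 to compound 4

The source may report more compounds than this note shows. Statements on the series, on what has been measured and on what is new or still open speak of the compounds shown alone.

Three compounds carry numbers in a functional assay on K562 cells (Homo sapiens) for cytotoxicity, read by trypan blue exclusion, with a stated time of 96 h; a higher number here means a weaker inhibitor, a lower number a stronger inhibitor. Compound 1 `COc1ccc(CS(=O)(=O)/C=C/c2c(F)cc(F)cc2F)cc1N` gives 800 nM, compound 2 `COc1ccc(CS(=O)(=O)/C=C/c2ccccc2OC)cc1N` gives 7500 nM, and compound 3 `COC(=O)CCNc1cc(CS(=O)(=O)/C=C/c2c(OC)cc(OC)cc2OC)ccc1OC` gives 1000 nM. Compound 3 holds the second highest of the three numbers; its nearest neighbour is compound 1, within the scatter, while compound 2 sits furthest off, beyond the scatter. Compound 4 `COc1cc(OC)c(/C=C/S(=O)(=O)Cc2ccc(OC)c(NC(C)(C)C(=O)O)c2)c(OC)c1` is not yet measured. It differs from compound 3 in one place: 1-carboxy-1-methylethyl in place of 2-(methoxycarbonyl)ethyl on a nitrogen on an aromatic ring. Among the compounds with values here, no measured pair shows this same change, so the expected step of a 2.0-fold higher number from compound 3 to compound 4 (0.30 log units; within the scatter) rests on judgement alone, most likely a small move toward a higher number, possibly none beyond the scatter. For compound 4 the estimate in this assay is 2000 nM, with a range from 600 nM to 7000 nM.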

Compound 4, half-maximal inhibitory concentration: 7.5 nM
For compound 4 the middle estimate is 270-fold (2.43 log units) above the measured one, and the stated range ends above it.
By their numbers in this assay, from the lowest: compound 4; then compounds 1 and 3 (each within the scatter of the next); then compound 2.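

In this assay, the group on a nitrogen on an aromatic ring matters greatly: 1-carboxy-1-methylethyl in place of 2-(methoxycarbonyl)ethyl gives a 130-fold lower number from compound 3 to compound 4 (2.12 log units; beyond the scatter) even though both groups hold the same heavy atoms. The earlier compounds shown here offered no step at this position, so this is its first reading. No available data account for the size of this step. The compounds shown leave open whether the carboxylic acid or the two methyl groups carry the gain. A 2-carboxyethyl group or the methyl ester of the 1-carboxy-1-methylethyl group would separate the two.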